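Chloro-to-hydrogen step on a purine-like series

This account rests on a few compounds, and the source may have more. Where it says the series, first, only, none or still open, it means among the compounds named here.

Measured:
compound 1 `ClCc1cccc(Cn2cnc3c(Cl)nc(Cl)nc32)c1` — 17000 nM
compound 2 `ClCc1cccc(Cn2cnc3nc(Cl)nc(Cl)c32)c1` — 6910 nM

In a functional assay on NCI-H522 cells (Homo sapiens) for cytotoxicity, read by sulforhodamine B assay, with a stated time of 48 h (on this read-out lower numbers stand for higher toxicity in this test and higher numbers for lower toxicity in this test), compound 1 gives 17000 nM, the highest number of the two measured; compound 2, an isomer with the same core atoms placed differently, gives 6910 nM, a gap beyond the scatter. Compound 3 `ClCc1cccc(Cn2cnc3c(Cl)ncnc32)c1` differs from compound 1 by hydrogen in place of chloro on an aromatic carbon. Within the data shown here, no step between measured compounds covers such a change. The step of a 1.2-fold higher number from compound 1 to compound 3 (0.07 log units; within the scatter) is expected to be small, at most near the scatter, leaning toward a higher number. Compound 3 is expected to give 20000 nM, within 7000 nM to 60000 nM.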

Compound 3, concentration lethal to 50% of the cells: > 100000 nM
Compound 3 gave a limit, no number; the forecaster's own chance of this, stated with the estimate: 10%; at least 5.0-fold (0.69 log units) between middle value and limit.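

In this assay, hydrogen in place of chloro on the aromatic carbon between two ring nitrogen atoms gives an at least 5.8-fold higher number from compound 1 to compound 3 (0.76 log units; beyond the scatter), so this position clearly affects the read-out, which the isomer pair alone did not show. The change marks a loss of toxicity in this test, and its full size stays unknown, as compound 3 carries a limit and not a number: the limit of > 100000 nM in this assay, at which 1 of the 3 values shown sits.

As far as these compounds go, whether chloro itself is needed at this position remains open. An amine or a methoxy group in its place would test whether other groups keep the toxicity of compound 1.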